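The compounds below may be only part of what the source reports. "The series", "measured", "known", "first", "only" and "open" are said of these compounds alone.

Working notes on the series in a functional assay on HepG2 cells (Homo sapiens) for antiproliferative activity, read by MTT assay, with a stated time of 48 h; a lower number here means a stronger inhibitor, a higher number a weaker inhibitor.

Two members of the shared core have been run so far. Compound 1 `COc1ccc(-n2nncc2CN2C(=O)C3(C(C#N)=C(N)Oc4c3c3nc5ccccc5nc3c3ccccc43)c3ccccc32)cc1` is one of them. In this assay compound 1 gives only a limit of the assay, > 50000 nM. Compound 2 `N#CC1=C(N)Oc2c(N)cc3nc4ccccc4nc3c2C12C(=O)N(Cc1cnnn1-c1cccc(Br)c1)c1ccccc12` is the other. In this assay compound 2 likewise gives only a limit, > 50000 nM. Where compound 2 stands is therefore not a number but a boundary: both values shown sit at the same limit (the limit of > 50000 nM in this assay, at which 2 of the 2 values shown sit), so no step between measured compounds can be stated, and the two values show only that neither compound reached a measurable half-maximal inhibitory concentration.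

Compound 3 `N#CC1=C(N)Oc2c(N)cc3nc4ccccc4nc3c2C12C(=O)N(Cc1cnnn1-c1cc(Cl)ccc1Cl)c1ccccc12` is the next member to be measured. It differs from compound 2 in one place: 2,5-dichlorophenyl in place of 3-bromophenyl on an aromatic nitrogen. Among the measured compounds shown here, no measured step bears on this change, and with both known values at the limit of > 50000 nM in this assay, at which 2 of the 2 values shown sit, there is no direction to read from the series. The expected step from compound 2 to compound 3 in this assay is none beyond the scatter, a step that the limit leaves unreadable from compound 2 to compound 3, with a strong chance that compound 3 again returns only a limit. Compound 3 is estimated at 60000 nM, within 20000 nM to 200000 nM.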

Compound 3, half-maximal inhibitory concentration: 33100 nM
Compound 3: the middle estimate sits 1.8-fold (0.26 log units) above what was measured; low and high end bracket the measured number.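

In this assay, among the compounds shown here, compound 3 gives 33100 nM, the first value that is a number and not a limit, so a substituted phenyl on this aromatic nitrogen of the five-membered ring can give a measurable half-maximal inhibitory concentration on the shared core. On these data alone, replacing 3-bromophenyl with 2,5-dichlorophenyl at this place gives an at least 1.5-fold lower number from compound 2 to compound 3 (0.17 log units; that floor lies within the scatter); this is only a floor, and the true size of the step remains unknown, so the change cannot yet be called a real gain. The series still rests largely on a single boundary: the limit of > 50000 nM in this assay, at which 2 of the 3 values shown sit.

As far as these compounds go, it remains open whether the measurable value belongs to the pair of chlorines, to where they sit on the phenyl ring, or to the absence of bromine, and one pair of compounds cannot separate these readings. A phenyl bearing a single chlorine would address the first of these questions, while a phenyl bearing an amine or a carboxylic acid would show whether this position tolerates groups of a quite different kind.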